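Replacing the Aryl Amino Group with Piperidine

The compounds below may be only part of what the source reports. "The series", "measured", "known", "first", "only" and "open" are said of these compounds alone.

In a functional assay on ECa-109 cells for inhibition, with ECa-109 cell line (Homo sapiens) as the target, read by sulforhodamine B assay (a higher number here means a weaker inhibitor, a lower number a stronger inhibitor), compound 1 `O=C1C(Nc2ccc(Br)cc2)=CC(=O)c2c1nc1n2[C@H]2OC[C@@H](O)[C@H]2OC1` gives 1980 nM. Compound 2 `Cc1ccc(NC2=CC(=O)c3c(nc4n3[C@H]3OC[C@@H](O)[C@H]3OC4)C2=O)cc1` gives > 4000 nM, which is a limit of the assay and not a number. The true position of compound 2 is therefore unknown, and only one side of it is marked.

The next structure, compound 3 `O=C1C(N2CCCCC2)=CC(=O)c2c1nc1n2[C@H]2OC[C@@H](O)[C@H]2OC1`, carries a much larger change than the one separating the first two: piperidin-1-yl in place of (4-methylphenyl)amino on a double-bonded ring carbon. Put simply, piperidin-1-yl stands in place of (4-methylphenyl)amino on a double-bonded ring carbon.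

Within the data shown here, only one measured step bears on this, and only loosely. That step, an at least 2.0-fold higher number from compound 1 to compound 2 (0.30 log units; that floor lies within the scatter), places methyl in place of bromo on an aromatic carbon, whereas here the whole aromatic ring leaves. Among the measured compounds shown here, no measured step shows what such an exchange does, so no direction can be argued from the data, and no step beyond the scatter is expected. The expected size is a step that the limit leaves unreadable from compound 2 to compound 3. A report of only a limit would be no surprise. Compound 3 is estimated at 4500 nM, with an expected range from 1500 nM to 15000 nM.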

Compound 3, half-maximal inhibitory concentration: > 8000 nM
Compound 3 ended at the assay's limit; the forecaster's own chance of this, stated with the estimate: 55%; middle value at least 1.7-fold (0.24 log units) away from the limit.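

In this assay compound 3 also ends at a limit of the assay and not at a number: the limit of > 8000 nM in this assay, at which 1 of the 3 values shown sits.

Even so, the limit is enough for a comparison with the one compound in this set that has a true value: piperidin-1-yl in place of (4-bromophenyl)amino on the double-bonded ring carbon gives an at least 4.0-fold higher number from compound 1 to compound 3 (0.60 log units; beyond the scatter), and this is the first step here that clearly lies beyond the scatter. At this position, then, a saturated ring attached through its nitrogen does not retain the inhibition seen with the (4-bromophenyl)amino group, while the step from compound 2 to compound 3 cannot be read, with a limit at both of its ends.

The compounds shown leave open which part of the exchange carries this loss, the aromatic ring or the hydrogen-bond donor, as both leave together in this step. A cyclohexylamino group at the same carbon would keep the amino hydrogen without the aromatic ring and so could begin to separate the two.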